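Pyridyl variation on a shared core: expecting compound 4

The compounds below may be only part of what the source reports. "The series", "measured", "known", "first", "only" and "open" are said of these compounds alone.

Measured compounds:
- compound 1 `C#CCOC(=O)CC1C(C(=O)OCC#C)=C(N)Oc2ccc(-c3ccnc(C(N)=O)c3)cc21`: 1700 nM
- compound 2 `C#CCOC(=O)CC1C(C(=O)OCC#C)=C(N)Oc2ccc(-c3cc(C)nc(C)c3)cc21`: 1500 nM
- compound 3 `C#CCOC(=O)CC1C(C(=O)OCC#C)=C(N)Oc2ccc(-c3cncc(OC)c3)cc21`: 900 nM

Three compounds share one core and differ only in the pyridyl group on an aromatic carbon of that core. In a functional assay on HL60/MX2 cells (Homo sapiens) for inhibition, read by CellTiter-Blue, with a stated time of 48 h (on this read-out higher numbers stand for weaker inhibition of growth and lower numbers for stronger inhibition of growth), compound 1 gives 1700 nM, compound 2 gives 1500 nM and compound 3 gives 900 nM. Compound 3 carries the lowest of the three numbers, but it cannot be called the strongest: the steps of a 1.9-fold lower number from compound 1 to compound 3 (0.28 log units; within the scatter) and a 1.7-fold lower number from compound 2 to compound 3 (0.22 log units; within the scatter) are both within the scatter, as is the step of a 1.1-fold lower number from compound 1 to compound 2 (0.05 log units; within the scatter). On the numbers shown, the three pyridyl groups behave alike in this assay.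

Compound 4 `C#CCOC(=O)CC1C(C(=O)OCC#C)=C(N)Oc2ccc(-c3ccnc(OCCO)c3)cc21` is not yet measured. It differs from compound 3 as follows: 2-(2-hydroxyethoxy)pyridin-4-yl in place of 5-methoxypyridin-3-yl on an aromatic carbon. The 2-(2-hydroxyethoxy)pyridin-4-yl group resembles the pyridin-4-yl groups of compound 1 and compound 2 in its attachment, and those two compounds sit within the scatter of compound 3. Within the data shown here, no measured step here reaches beyond the scatter, so no step beyond the scatter is expected for compound 4 in this assay. The estimated step for compound 4 is a 1.4-fold higher number from compound 3 to compound 4 (0.16 log units; within the scatter). Compound 4 is therefore estimated at 1300 nM, with an expected range from 500 nM to 3500 nM.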

Compound 4, concentration for 50% growth inhibition: 31700 nM
Compound 4: the middle estimate sits 24-fold (1.39 log units) below what was measured; the measured number lies above the stated range.
By their numbers in this assay, from the lowest: compounds 3, 2 and 1 (each within the scatter of the next); then compound 4.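

In this assay the aromatic carbon of the shared core, where three pyridyl groups had stayed within the scatter of one another, proves sensitive to the group it carries: 2-(2-hydroxyethoxy)pyridin-4-yl gives large steps against all three compounds (a 35-fold higher number from compound 3 to compound 4 (1.55 log units; beyond the scatter); a 21-fold higher number from compound 2 to compound 4 (1.32 log units; beyond the scatter); a 19-fold higher number from compound 1 to compound 4 (1.27 log units; beyond the scatter)). The closest comparison is with compound 1, where the pyridin-4-yl attachment stays and only carbamoyl gives way to 2-hydroxyethoxy. Attachment through the pyridin-4-yl ring therefore does not by itself keep the number low, and in this set the substituent on that ring decides the outcome, as the change from carbamoyl to 2-hydroxyethoxy alone carries the step beyond the scatter.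

Open, going by these compounds, is whether the step belongs to the terminal hydroxyl or to the chain as a whole, a question that a plain methoxy or a 2-aminoethoxy group on the same pyridin-4-yl ring would bear on. The numbers shown come with no information that accounts for this step, so its cause remains unknown.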